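This account rests on a few compounds, and the source may have more. Where it says the series, first, only, none or still open, it means among the compounds named here.

Measured compounds:
compound 1, `O=c1ccc(-c2ccccc2)nn1CCCCNC(=S)Nc1ccccc1` — a functional assay on the whole organism with Rattus norvegicus as the target; a lower number here means that less compound is needed, a higher number that more compound is needed for the effect: > 100 mg/kg
compound 2, `C=CCNC(=S)NCCCCn1nc(-c2ccccc2)ccc1=O` — this assay: 78.6 mg/kg

Within the data shown here, compound 2 holds the only number in this assay; the value given for compound 1 is a limit of the assay, not a number (the limit of > 100 mg/kg in this assay, at which 1 of the 2 values shown sits). The step of an at least 1.2-fold lower number from compound 1 to compound 2 (0.10 log units; that floor lies within the scatter) is therefore only a floor, and that floor lies within the scatter.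

Compound 3, `CN(C)/C(=N/CCCn1nc(-c2ccccc2)ccc1=O)NC#N`, differs from compound 2 in one place: a group of 8 heavy atoms (4 carbon, 4 nitrogen; no ring) in place of a group of 8 heavy atoms (5 carbon, 2 nitrogen, 1 sulfur; no ring), on a saturated chain carbon, three bonds along the chain from an aromatic nitrogen. Among the measured compounds shown here, the only measured step, an at least 1.2-fold lower number from compound 1 to compound 2 (0.10 log units; that floor lies within the scatter), concerns an exchange of an allyl for a phenyl on an amide-type nitrogen and gives no firm size; it does not touch the part of the molecule changed here. For the measured compounds named here, with no step bearing on this change, the expectation is that compound 3 stays near compound 2, with no step beyond the scatter in either direction, although the absence of a reference step leaves the uncertainty wide. For compound 3 the expected value in this assay is 80 mg/kg, between 30 mg/kg and 250 mg/kg, which means an expected step of a 1.0-fold higher number from compound 2 to compound 3 (0.01 log units; within the scatter).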

Compound 3, dose for half-maximal effect: 93.1 mg/kg
The estimate for compound 3 lay 1.2-fold (0.07 log units) below the measured number, within the range that was stated.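

In this assay, among these compounds, the exchange of the group of 8 heavy atoms (5 carbon, 2 nitrogen, 1 sulfur; no ring) for the group of 8 heavy atoms (4 carbon, 4 nitrogen; no ring), on a saturated chain carbon, three bonds along the chain from an aromatic nitrogen, gives a 1.2-fold higher number from compound 2 to compound 3 (0.07 log units; within the scatter) and so provides the first step here with a firm size. Among the compounds shown here, the earlier pair left this position untouched, so this is also the first reading of what a change there does. Sulfur leaves, a triple bond enters and the counts of hydrogen-bond donors and acceptors on the group differ, yet compound 2 and compound 3 remain within the scatter of each other, and the two groups are not told apart by this read-out.

On these data alone, whether an amine or a carboxylic acid at this position would also stay within the scatter of compound 2 remains open. For compound 1 the value is a limit of the assay and not a number, so the size of its step remains unknown: the limit of > 100 mg/kg in this assay, at which 1 of the 3 values shown sits.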